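Nitro in place of fluoro at the chain end

A few compounds are considered here, and "the series" means these few. Any claim that something is new, unique, unknown or untested is made for them only; others in the source may bear on it.

Compound 3 `O=C(NCCCCc1ccc(F)cc1)n1c(=O)oc2ccccc21` stands highest of the three measured numbers in an assay on HEK293 cells for inhibition of acid ceramidase (Homo sapiens), with a stated time of 10 min (on this read-out lower numbers stand for stronger inhibition and higher numbers for weaker inhibition), giving 75 nM; its nearest neighbour is compound 1 `O=C(NCCCCc1ccccc1)n1c(=O)oc2ccccc21`, which gives 64 nM, and the furthest is compound 2 `COc1ccc(CCCCNC(=O)n2c(=O)oc3ccccc32)cc1`, which gives 63 nM, both within the scatter of compound 3. The step of a 1.2-fold higher number from compound 1 to compound 3 (0.07 log units; within the scatter) and the step of a 1.2-fold higher number from compound 2 to compound 3 (0.08 log units; within the scatter) are both within the scatter, as is a 1.0-fold lower number from compound 1 to compound 2 (0.01 log units; within the scatter). Compound 4 `O=C(NCCCCc1ccc([N+](=O)[O-])cc1)n1c(=O)oc2ccccc21` differs from compound 3 by nitro in place of fluoro on an aromatic carbon. For the measured compounds named here, the steps that bear on this change are those that alter the same aromatic carbon: hydrogen, methoxy and fluoro at this place all give numbers within the scatter of one another, so none of the measured steps at this position exceeds the scatter. Going by the values given here, no measured compound carries nitro at this place, so the expectation rests only on the three groups already seen there. For compound 4 a step in this assay of no more than the scatter is therefore expected, in either direction, a 1.1-fold lower number from compound 3 to compound 4 (0.03 log units; within the scatter). The estimate for compound 4 in this assay is 70 nM, with a range from 35 nM to 140 nM.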

Compound 4, half-maximal inhibitory concentration: 312 nM
Beside the measured number, compound 4's estimate is 4.5-fold (0.65 log units) below it; the whole stated range lies below it.
By their numbers in this assay, from the lowest: compounds 2, 1 and 3 (each within the scatter of the next); then compound 4.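

In this assay this aromatic carbon, para to a large group, proves sensitive to what it carries: there is a 4.2-fold higher number from compound 3 to compound 4 (0.62 log units; beyond the scatter) when nitro enters for fluoro, whereas hydrogen, methoxy and fluoro at the same place stay within the scatter of one another. Nitro also stands apart from the other two groups, with a 5.0-fold higher number from compound 2 to compound 4 (0.69 log units; beyond the scatter) for nitro replacing methoxy and a 4.9-fold higher number from compound 1 to compound 4 (0.69 log units; beyond the scatter) for nitro replacing hydrogen, so the earlier flat read of this position holds for three of the four groups and fails for the fourth. Nothing measured here speaks to what lies behind this step.

From the compounds shown here alone, whether the higher number belongs to nitro alone remains open, since nitrile, trifluoromethyl, an amine and a carboxylic acid at the same carbon could each either join compound 4 or stay with compounds 1, 2 and 3. Also open, going by these compounds, is whether nitro gives a step of this size at another carbon of the same ring, or on a shorter or longer chain between that ring and the shared core.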